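Series notes: benzylpiperazine aryl swap toward compound 3

This account rests on a few compounds, and the source may have more. Where it says the series, first, only, none or still open, it means among the compounds named here.

Measured so far:
- compound 1 `c1ccc(CN2CCN(CCCc3c[nH]c4ccc(-n5cnnc5)cc34)CC2)nc1` gives 0.4 nM
- compound 2 `c1c[nH]c(CN2CCN(CCCc3c[nH]c4ccc(-n5cnnc5)cc34)CC2)n1` gives 1.6 nM

Both numbers come from an assay on CHO cells for displacement of a labelled ligand from 5-hydroxytryptamine receptor 1D (Homo sapiens); a higher number here means a weaker inhibitor, a lower number a stronger inhibitor. Compound 2 has the higher of the two numbers; the step of a 4.0-fold higher number from compound 1 to compound 2 (0.60 log units; beyond the scatter) is modest but beyond the scatter, so compound 2 is the weaker of the pair.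

Compound 3 `CC(=O)Nc1ccc(CN2CCN(CCCc3c[nH]c4ccc(-n5cnnc5)cc34)CC2)cc1` is not yet measured. It differs from compound 2 as follows: 4-acetamidophenyl in place of 1H-imidazol-2-yl on a saturated chain carbon bound to an amine nitrogen in a ring. Going by the values given here, the only measured step that bears on this position is a 4.0-fold higher number from compound 1 to compound 2 (0.60 log units; beyond the scatter), which shows that exchanging the aromatic group on that chain carbon moves the number by a modest amount. Among the compounds with values here, no measured compound carries a six-membered carbon-only ring at this place, so the direction is uncertain; the size is expected to stay modest.

For compound 3 the estimate in this assay is 1 nM, with a range from 0.25 nM to 4 nM. The step this implies, a 1.6-fold lower number from compound 2 to compound 3 (0.20 log units; within the scatter), is an expectation only.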

Compound 3, half-maximal inhibitory concentration: 2.5 nM
The estimate for compound 3 lay 2.5-fold (0.40 log units) below the measured number; the measured number falls inside the stated range.
By their numbers in this assay, from the lowest: compound 1; then compounds 2 and 3 (each within the scatter of the next).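

In this assay, the place on a saturated chain carbon bound to an amine nitrogen in a ring accepts 4-acetamidophenyl, with 10 heavy atoms, as well as 1H-imidazol-2-yl, with 5: the step is a 1.6-fold higher number from compound 2 to compound 3 (0.19 log units; within the scatter) and leaves compounds 2 and 3 unresolved. The comparison with pyridin-2-yl reads a 6.3-fold higher number from compound 1 to compound 3 (0.80 log units; beyond the scatter) and, with the earlier step, leaves compound 1 as the strongest inhibitor of the three, so a larger group here is tolerated without matching pyridin-2-yl. No measurement offered here explains these numbers.

Open, going by these compounds, is whether the acetamido group contributes at all, which plain phenyl would test. Also open, on these data alone, is how a carboxylic acid on that phenyl, or a longer chain at this place, would read.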